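Aryl-pyrazole acetonitriles: cytotoxicity at a single low concentration

This account rests on a few compounds, and the source may have more. Where it says the series, first, only, none or still open, it means among the compounds named here.

Three compounds of the series have been run through a functional assay on SF-268 cells (Homo sapiens) for cytotoxicity, read by sulforhodamine B assay, with a stated time of 48 h, tested at 0.01 uM; on this read-out higher numbers stand for a weaker effect at the one concentration tested and lower numbers for a stronger effect. Compound 1 `COc1cc(C)cc(-c2c(-c3ccnc(-c4ccc(C(C)=O)cc4)c3)cnn2CC#N)c1` gives 96%. Compound 2 `COc1cc(C)cc(-c2nn(CC#N)cc2-c2ccc(-c3cccc(C(C)=O)c3)nc2)c1` gives 94%. Compound 3 `Cc1cc(O)cc(-c2nn(CC#N)cc2-c2ccnc(-c3ccc(Oc4ccccc4)cc3)c2)c1` gives 91%. The three numbers all sit close to full residual activity and lie within the usual scatter of one another: the gap from compound 3 to compound 2 and the gap from compound 3 to compound 1 are both inside that scatter, so none of the three can be set apart from the others on this read-out.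

The next compound, compound 4 `Cc1cc(O)cc(-c2nn(CC#N)cc2-c2ccnc(-c3ccc(N(C)C)cc3)c2)c1`, is compared with compound 3 in one place (dimethylamino in place of phenoxy on an aromatic carbon). Going by the values given here, no pair of measured compounds differs in one place, so nothing measured so far tells what this kind of change does in this assay. With all three measured numbers crowded near the top of the scale, the expectation for compound 4 is a step of a number 1 percentage points higher from compound 3 to compound 4 (within the scatter) that stays within the scatter, in no particular direction. Compound 4 is therefore estimated to give 92% in this assay, within a range from 80% to 100%.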

Compound 4, a percentage reported as activity, at one concentration (the size of the read-out at that concentration, not a potency): 90%
Beside the measured number, compound 4's estimate is 2 percentage points above it, and the stated range covers the measured number.
By their numbers in this assay, from the lowest: compounds 4, 3, 2 and 1 (each within the scatter of the next).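

In this assay, going by these compounds alone, dimethylamino in place of phenoxy on an aromatic carbon, para to a large group, gives a number 1 percentage points lower from compound 3 to compound 4 (within the scatter), and this is the first one-place comparison available. The read-out therefore does not separate the two groups at this position, even though the entering group has 3 heavy atoms and no ring, while the leaving group has 7 heavy atoms and a six-membered aromatic ring. Nothing available speaks to the reason for this result.

Going by these compounds, it remains open whether a carboxylic acid, a fluorine or a longer amine chain on this carbon would read apart from phenoxy and dimethylamino. On these data alone, it is also open whether the same exchange reads alike on a compound carrying methoxy in place of hydroxy.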